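A few compounds are considered here, and "the series" means these few. Any claim that something is new, unique, unknown or untested is made for them only; others in the source may bear on it.

Compound 1 `CCOC(=O)C1=C(Nc2ccccc2)S/C(=C\c2ccc(OC)cc2)C1=O`: 32.9%
Compound 2 `CCOC(=O)C1=C(Nc2ccccc2)S/C(=C\c2ccc([N+](=O)[O-])c(O)c2)C1=O`: 51.2%

In a functional assay on JAR cells (Homo sapiens) for inhibition, read by MTT assay, with a stated time of 72 h, tested at 10 uM (a lower number here means less inhibition, a higher number more inhibition at the concentration tested (going by the name of the read-out)), compound 2 gives 51.2%, the higher of the two numbers; compound 1 gives 32.9%, a gap beyond the scatter. Compound 3 `CCOC(=O)C1=C(Nc2ccccc2)S/C(=C\c2ccc(Br)c(O)c2)C1=O` has not been measured in this assay. It differs from compound 2 by bromo in place of nitro on an aromatic carbon. Among the compounds with values here, no measured pair shows this change, so the size of the step is open. The step of a number 6.2 percentage points lower from compound 2 to compound 3 (within the scatter) is expected to be small, downward if anything, and within the scatter. For compound 3 the estimate in this assay is 45%, with a range from 25% to 65%.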

Compound 3, a percentage reported as inhibition, at one concentration (the size of the read-out at that concentration, not a potency): 39.8%
Compound 3: the middle estimate sits 5.2 percentage points above what was measured; low and high end bracket the measured number.
By their numbers in this assay, from the lowest: compounds 1 and 3 (each within the scatter of the next); then compound 2.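

In this assay, the aromatic carbon ortho to a hydroxy group now has a measured step: bromo in place of nitro gives a number 11.4 percentage points lower from compound 2 to compound 3 (beyond the scatter), so the number is lower with bromo at this carbon. Against the 4-methoxyphenyl compound, the 4-bromo-3-hydroxyphenyl group gives a number 6.9 percentage points higher from compound 1 to compound 3 (within the scatter) and the two cannot be told apart. Nothing measured explains the nitro-to-bromo step.

As far as these compounds go, an amine or a carboxylic acid at this carbon remains open. So does the contribution of the hydroxy group alone, which no single-place pair here isolates.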